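A few compounds are considered here, and "the series" means these few. Any claim that something is new, unique, unknown or untested is made for them only; others in the source may bear on it.

Measured so far in a functional assay on SW480 cells (Homo sapiens) for cytotoxicity, read by MTT assay, with a stated time of 48 h; on this read-out higher numbers stand for weaker inhibition and lower numbers for stronger inhibition:
compound 1, `COc1cc([C@@H]2C[C@]2(CO)C(=O)NCc2ccc(C)cc2)cc(OC)c1OC`, gives 26800 nM
compound 2, `COc1cc([C@H]2C[C@]2(CO)C(=O)Nc2ccccc2Cl)cc(OC)c1OC`, gives 40200 nM
compound 3, `CCOC(=O)[C@]1(C(=O)NCc2ccc(C)cc2)C[C@H]1c1cc(OC)c(OC)c(OC)c1`, gives 36400 nM

All three numbers lie within the usual scatter of one another, so no order among them is claimed. Compound 1 and compound 3 share one core; compound 2 and compound 4, the latter being `CCOC(=O)[C@]1(C(=O)Nc2ccccc2Cl)C[C@@H]1c1cc(OC)c(OC)c(OC)c1` and not yet measured in this assay, share another. The difference between the two cores is not broken down here.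

The change from compound 1 to compound 3 is ethoxycarbonyl in place of hydroxymethyl on a saturated ring carbon. It made a 1.4-fold higher number from compound 1 to compound 3 (0.13 log units; within the scatter). The change from compound 2 to compound 4 is ethoxycarbonyl in place of hydroxymethyl on a saturated ring carbon; its place is described in the same words, so it is the same change carried onto the other core.

With a single prior instance, and that within the scatter, the corresponding step is expected at a 1.3-fold higher number from compound 2 to compound 4 (0.11 log units; within the scatter), resting on a 1.4-fold higher number from compound 1 to compound 3 (0.13 log units; within the scatter). Starting from compound 2 at 40200 nM, compound 4 is expected at 52000 nM, in a range from 25000 nM to 105000 nM.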

Compound 4, half-maximal inhibitory concentration: > 100000 nM
Compound 4: only a limit was reported (the forecaster's own chance of this, stated with the estimate: 15%); at least 1.9-fold (0.28 log units) between middle value and limit.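

In this assay, ethoxycarbonyl in place of hydroxymethyl on a saturated ring carbon gives an at least 2.4-fold higher number from compound 2 to compound 4 (0.39 log units; beyond the scatter), so on this core the change has a readable cost. Compound 4 reaches only a limit, > 100000 nM, which is a bound and not a measured number. Neither core shows a step towards a lower number, but this pair of results does not establish that the size of the step carries from one core to the other: the same change on two cores in this assay, a 1.4-fold higher number (0.13 log units; within the scatter) from compound 1 to compound 3 and an at least 2.4-fold higher number (0.39 log units; beyond the scatter) from compound 2 to compound 4; the limit leaves it open whether they differ

The compounds shown leave open the actual size of the step on the core of compound 2, and whether the result is particular to ethoxycarbonyl or would also appear with a carboxylic acid or an amine-bearing chain on that saturated ring carbon. Among the compounds shown here, with only two pairs available, they also leave open whether the change would behave alike on cores carrying other amide groups.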